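The compounds below may be only part of what the source reports. "The series", "measured", "known", "first", "only" and "open" are said of these compounds alone.

Compound 1 `Cc1cn(/C=C/C=O)c(=O)[nH]c1=O` carries a 2-formylethenyl group on its core. In a functional assay on HeLa cells (Homo sapiens) for inhibition (on this read-out lower numbers stand for stronger inhibition and higher numbers for weaker inhibition), compound 1 gives 100000 nM. Compound 2 `CC(=O)/C=C/n1cc(C)c(=O)[nH]c1=O` differs from compound 1 by methyl in place of hydrogen on a carbonyl carbon. In this assay compound 2 reaches only a limit, > 100000 nM. The step of a number no lower from compound 1 to compound 2 (the limit leaves the size open) is therefore open in size, and that limit is the only such reading among these values (the limit of > 100000 nM in this assay, at which 1 of the 3 values shown sits).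

Compound 3 `O=C/C=C/n1c(=O)ccn([C@H]2C[C@H](O)[C@@H](CO)O2)c1=O` carries the same 2-formylethenyl group on a different core; the difference between the two cores is not broken down here. In this assay compound 3 gives 15000 nM, the lowest number of the two measured values, with compound 1 showing a higher number by a margin beyond the usual scatter.

Compound 4 `CC(=O)/C=C/n1c(=O)ccn([C@H]2C[C@H](O)[C@@H](CO)O2)c1=O`, not yet measured, differs from compound 3 by methyl in place of hydrogen on a carbonyl carbon, the same change as that from compound 1 to compound 2, at the same kind of place. Since that earlier step a number no lower from compound 1 to compound 2 (the limit leaves the size open) gave a number no lower, the step from compound 3 to compound 4 is expected to be a 2.7-fold higher number from compound 3 to compound 4 (0.43 log units; beyond the scatter). In this assay compound 4 is therefore estimated at 40000 nM, expected to fall between 10000 nM and 150000 nM.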

Compound 4, half-maximal inhibitory concentration: 6000 nM
The estimate for compound 4 lay 6.7-fold (0.82 log units) above the measured number, and the stated range ends above it.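

Within this assay the swap of formyl for acetyl, methyl in place of hydrogen on a carbonyl carbon, gives a 2.5-fold lower number from compound 3 to compound 4 (0.40 log units; beyond the scatter) on the core shared by these two compounds, a modest step that shows the change need not raise the number. Compound 2 reaches only a limit, > 100000 nM, and so the step on the core of compound 1 cannot be read in size. One core thus gives a readable step and the other does not, which shows neither that the change carries from one core to the other nor that it fails to: the same change on two cores in this assay, a number no lower (the limit leaves the size open) from compound 1 to compound 2 and a 2.5-fold lower number (0.40 log units; beyond the scatter) from compound 3 to compound 4; the limit leaves it open whether they differ.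

The compounds shown leave open how a longer chain such as propanoyl, or an amine or a carboxylic acid in place of the hydrogen on the carbonyl carbon, would read on either core. Going by these compounds alone, they also leave open what the same change would give on any third core, as only two cores appear here.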